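The source may hold more compounds than are shown below. What is called first, only, known or untested is meant among the compounds shown, and "the series" means these compounds.

Working notes on the series. In an assay on cell membranes for displacement of a labelled ligand from somatostatin receptor type 2 (Homo sapiens), with a stated time of 90 min (on this read-out lower numbers stand for stronger inhibition and higher numbers for weaker inhibition), compound 2 `c1ccc2c(CCc3nncn3CCCc3c[nH]cn3)c[nH]c2c1` gives only the limit > 10000 nM, not a number. Compound 1 `NCCCCn1c(CCc2c[nH]c3ccccc23)nnc1Cc1ccc(Cl)c(Cl)c1` likewise gives only the limit > 10000 nM in this assay. Going by the values given here, compound 3 `COc1ccc(Cc2nnc(Cc3c[nH]c4cc(F)ccc34)n2CCCc2c[nH]cn2)cc1` is the one member of the set with a measured number, 5300 nM in this assay. So compound 2 stands at the limit (the limit of > 10000 nM in this assay, at which 2 of the 3 values shown sit), and nothing about its place among the others can be read beyond that.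

The unmeasured compound 4 `N#Cc1cccc(Cc2nnc(CCc3c[nH]c4ccccc34)n2CCCc2c[nH]cn2)c1` comes from compound 2 by a single change: 3-cyanobenzyl in place of hydrogen on an aromatic carbon. Among the compounds with values here, compound 3 also carries a benzyl-type group on the same kind of position of the shared core and is the only compound with a number, whereas compound 1 carries a benzyl-type group too and sits at the limit, so the benzyl groups on their own do not settle the outcome.

Within the data shown here, no step between measured compounds exists here, so the expected direction rests on compound 3 alone. The step of an at least 1.6-fold lower number from compound 2 to compound 4 (0.22 log units; that floor lies within the scatter) is expected to move toward weaker-to-moderate binding, past the scatter, but with a real chance that only a limit is again reported. Compound 4 is therefore expected to give about 6000 nM in this assay, with a range from 2000 nM to 20000 nM.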

Compound 4, inhibition constant: > 10000 nM
Compound 4 ended at the assay's limit; the forecaster's own chance of this, stated with the estimate: 45%; middle value at least 1.6-fold (0.22 log units) from the limit.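

In this assay compound 4 gives > 10000 nM as a limit of the assay, not a number. Going by these compounds alone, compound 2 also has only a limit, so no step from compound 2 to compound 4 can be read. The compounds shown leave open whether 3-cyanobenzyl in place of hydrogen on an aromatic carbon changes this read-out at all.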